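Swapping the Five-Membered Ring on a Sulfonamide Series

The source may hold more compounds than are shown below. What is called first, only, known or untested is meant among the compounds shown, and "the series" means these compounds.

Three sulfonyl compounds have been tested in a functional assay on BGC-823 cells (Homo sapiens) for inhibition, read by MTT assay, tested at 10 uM; a higher number here means more inhibition at the concentration tested (going by the name of the read-out), a lower number less inhibition. Compound 1 `O=[N+]([O-])c1ccc2c(c1)N(S(=O)(=O)c1ccc(-c3cnc(C4CC4)o3)cc1)CC2` gives 97.7%. Compound 2 `O=S(=O)(c1ccc(-c2cnc(C3CC3)o2)cc1)n1ccc2ccccc21` gives 37.9%. Compound 3 `O=S(=O)(c1ccc(-c2nnc(C3CC3)o2)cc1)N1CCc2ccccc21` gives 27.7%, which is the lowest of the three numbers: the gap to compound 2 is beyond the usual scatter, and the gap to compound 1 is far beyond it.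

Compound 4 `O=S(=O)(c1ccc(-c2cnc(C3CC3)s2)cc1)N1CCc2ccccc21` has not yet been measured. It differs from compound 3 in one place: 2-cyclopropyl-1,3-thiazol-5-yl in place of 5-cyclopropyl-1,3,4-oxadiazol-2-yl on an aromatic carbon. Among the measured compounds shown here, no pair of measured compounds shows this particular swap, so the data give no direct guide to its effect. Both groups carry a cyclopropyl on a five-membered aromatic ring, and the rest of the molecule is the same. The step from compound 3 to compound 4 in this assay is therefore expected to be small, with a slight upward lean, as a number 7.3 percentage points higher from compound 3 to compound 4 (within the scatter). Compound 4 is estimated to give 35% in this assay, in a range from 15% to 60%.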

Compound 4, a percentage reported as inhibition, at one concentration (the size of the read-out at that concentration, not a potency): 38.5%
Beside the measured number, compound 4's estimate is 3.5 percentage points below it; the range from low to high includes it.
By their numbers in this assay, from the lowest: compound 3; then compounds 2 and 4 (each within the scatter of the next); then compound 1.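

On an aromatic carbon para to a large group, in this assay, 2-cyclopropyl-1,3-thiazol-5-yl in place of 5-cyclopropyl-1,3,4-oxadiazol-2-yl gives a number 10.8 percentage points higher from compound 3 to compound 4 (beyond the scatter) as a modest step. The result shows that the read-out at this position depends on which five-membered aromatic ring is present, even with the cyclopropyl retained and the rest of the molecule unchanged. Nothing available bears on why the number rises with this swap.

On these data alone, it remains open whether an amine or a longer chain in place of the cyclopropyl would keep, lose or raise the inhibition seen with this ring. Also open, as far as these compounds go, is whether the same ring swap would give a step of similar size on the core of compound 1, which carries a nitro group.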